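This account rests on a few compounds, and the source may have more. Where it says the series, first, only, none or still open, it means among the compounds named here.

Measured in a functional assay on M21 cells (Homo sapiens) for antiproliferative activity, read by sulforhodamine B assay, with a stated time of 48 h; a lower number here means a stronger inhibitor, a higher number a weaker inhibitor:
- compound 1 `CCN1CCN(c2ccc(S(=O)(=O)Oc3cccc(OC)c3)cc2)C1=O`: 7000 nM
- compound 2 `CCN1CCN(c2ccc(S(=O)(=O)Oc3ccc(OC)c(OC)c3)cc2)C1=O`: 35000 nM

Compound 2, at 35000 nM, has the higher of these two numbers, which makes it the weaker inhibitor of the pair. The next compound, compound 3 `CCCCN1CCN(c2ccc(S(=O)(=O)Oc3ccc(OC)c(OC)c3)cc2)C1=O`, changes it at a different place: ethyl in place of hydrogen on a saturated chain carbon, two bonds along the chain from an amide-type nitrogen in a ring. In short, the ethyl group of compound 2 becomes a butyl group in compound 3.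

Among the compounds with values here, the only measured step, a 5.0-fold higher number from compound 1 to compound 2 (0.70 log units; beyond the scatter), is modest and came from methoxy in place of hydrogen on an aromatic carbon. That is a change at another place, so it gives no direction here. No step beyond the scatter is therefore expected in this assay. The expected size is a 1.4-fold lower number from compound 2 to compound 3 (0.15 log units; within the scatter). Compound 3 is estimated at 25000 nM, with an expected range of 8000 nM to 70000 nM.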

Compound 3, half-maximal inhibitory concentration: > 100000 nM
Compound 3 gave a limit, no number; the forecaster's own chance of this, stated with the estimate: 15%; middle value at least 4.0-fold (0.60 log units) from the limit.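

Compound 1 and compound 2 differ only by a methoxy group on an aromatic carbon, so they showed nothing about the alkyl group on the amide-type nitrogen in a ring. Extending ethyl to butyl at this position gives an at least 2.8-fold higher number from compound 2 to compound 3 (0.45 log units; beyond the scatter) in this assay, which shows that this position responds to the change and that, for this one pair, the longer chain goes with weaker inhibition. The value of compound 3 is a limit and not a number: the limit of > 100000 nM in this assay, at which 1 of the 3 values shown sits.

The compounds shown leave open whether a methyl group would give a lower number than the ethyl group of compound 2, and whether a propyl group would already weaken inhibition as the butyl group does. Also open, going by these compounds, is whether a chain ending in an amine or a carboxylic acid would behave like the plain butyl chain of compound 3.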